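The source may hold more compounds than are shown below. What is called first, only, known or untested is meant among the compounds shown, and "the series" means these compounds.

In a functional assay on GOTO cells (Homo sapiens) for cytotoxicity, read by MTT assay, with a stated time of 3 days (a lower number here means a stronger inhibitor, a higher number a weaker inhibitor), three compounds with a shared core have been measured. Compound 1 (`CNc1nc(SCc2nc3ccccc3[nH]2)nc(-c2ccccc2)c1C#N`) gives 3.28 nM while compound 2 (`N#Cc1c(NNC(N)=S)nc(SCc2nc3ccccc3[nH]2)nc1-c1ccccc1`) gives 2.55 nM and compound 3 (`N#Cc1c(-c2ccccc2)nc(SCc2nc3ccccc3[nH]2)nc1N1CCN(S(=O)(=O)c2ccccc2)CC1`), which carries a phenylsulfonyl group, gives 5.81 nM on the same read-out. Compound 3 thus lies within the scatter of compound 1 and beyond the scatter of compound 2, on the higher side. Compound 4 (`N#Cc1c(-c2ccccc2)nc(SCc2nc3ccccc3[nH]2)nc1N1CCN(S(=O)(=O)c2ccccc2[N+](=O)[O-])CC1`) differs from compound 3 by nitro in place of hydrogen on an aromatic carbon in a single change, nitro in place of hydrogen on an aromatic carbon, ortho to a large group, so that phenylsulfonyl becomes (2-nitrophenyl)sulfonyl. Among the compounds with values here, the one measured step (a 1.3-fold lower number from compound 1 to compound 2 (0.11 log units; within the scatter)) is a different change, on a nitrogen on an aromatic ring, and it stays within the scatter. Within the data shown here, no measured step touches the phenylsulfonyl group, so the guidance is weak, and no step beyond the scatter is expected in this assay here. Compound 4 is expected to read 5.5 nM and to fall between 2.5 nM and 13 nM by this estimate. This estimate means a 1.1-fold lower number from compound 3 to compound 4 (0.02 log units; within the scatter) as the expected step.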

Compound 4, half-maximal inhibitory concentration: 3 nM
The estimate for compound 4 lay 1.8-fold (0.26 log units) above the measured number; measured number inside the range.
By their numbers in this assay, from the lowest: compounds 2, 4, 1 and 3 (each within the scatter of the next, the first and the last beyond it).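

In this assay, nitro in place of hydrogen on an aromatic carbon, ortho to a large group, gives a 1.9-fold lower number from compound 3 to compound 4 (0.29 log units; within the scatter), and this is the first step shown that touches the phenylsulfonyl group. The step adds nitro to that ring, yet this assay does not separate phenylsulfonyl from (2-nitrophenyl)sulfonyl, so this place on the ring accepts nitro without a change beyond the scatter. Nothing available explains this reading.

The compounds shown leave open whether an amine, a carboxylic acid or a methoxy group at this carbon would also stay within the scatter of compound 3, and whether nitro on another carbon of the same ring would do so. With a single substituent tried here, they give no trend for this ring.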